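Enantiomer swap in the oxalamide series

A few compounds are considered here, and "the series" means these few. Any claim that something is new, unique, unknown or untested is made for them only; others in the source may bear on it.

Working notes. The series shares the core of compound 1 `N#Cc1cnn(-c2ccccc2)c1NC(=O)C(=O)Nc1c(C#N)cnn1-c1ccccc1`. In a functional assay on the whole organism (strain Wistar albino) for inhibition, with Rattus norvegicus as the target, read by paw edema, in the formalin test, with a stated time of 1 h, at a dose of 20 mg/kg by the oral route (on this read-out lower numbers stand for less inhibition and higher numbers for more inhibition at the one dose given (going by the name of the read-out)), compound 1 gives 43%. Compound 2 `CC(NC(=O)C(=O)Nc1c(C#N)cnn1-c1ccccc1)c1ccccc1` gives 39% in this assay, and compound 3 `C[C@@H](NC(=O)C(=O)Nc1c(C#N)cnn1-c1ccccc1)c1ccccc1` gives 39%, level with compound 2 at the digits printed, with compound 1 a few points away inside the scatter. For the measured compounds named here, the only single-place step measured is no change at the digits printed from compound 2 to compound 3 (within the scatter); the evidence bearing on it is the fact that one of compounds 2 and 3 is drawn with a defined configuration and the other without, at the place where they differ, the undefined drawing against the R form. Compound 4 `C[C@H](NC(=O)C(=O)Nc1c(C#N)cnn1-c1ccccc1)c1ccccc1` differs from compound 3 thus: the two compounds have the same atoms and bonds and differ only in configuration as drawn: 1 of 1 stereo elements differ; a stereocentre at a saturated chain carbon is drawn R in compound 3 and S in compound 4. Since the defined R form gave no movement against the undefined material, no step beyond the scatter is expected in this assay. Compound 4 is estimated at 39%, with a range from 30% to 48%. The expected step is no change at the digits printed from compound 3 to compound 4 (within the scatter).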

Compound 4, a percentage reported as inhibition, in the whole organism at one dose (the size of the read-out at that dose, not a potency): 41%
Compound 4: the middle estimate sits 2 percentage points below what was measured, within the range that was stated.
By their numbers in this assay, from the lowest: compounds 2, 3, 4 and 1 (each within the scatter of the next).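

Compound 4 completes the enantiomer pair, so both configurations at this saturated chain carbon can now be compared directly in this assay. The swap gives a number 2 percentage points higher from compound 3 to compound 4 (within the scatter), and the S form against the undefined drawing gives a number 2 percentage points higher from compound 2 to compound 4 (within the scatter). At this one dose, the configuration at this stereocentre therefore does not separate the two forms beyond the scatter, in a pair where: the fact that compounds 3 and 4 differ only in the configuration as drawn

From the compounds shown here alone, whether a longer chain or an amine in place of the methyl on this carbon would move the number beyond the scatter stays open. A single dose also leaves open how the two forms compare at other doses.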